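The compounds below may be only part of what the source reports. "The series", "measured", "known", "first", "only" and "open" are said of these compounds alone.

Working notes on the series. For the measured compounds named here, in a functional assay on HT cells (Homo sapiens) for antiproliferative activity, read by fluorescence, with a stated time of 72 h (a higher number here means a weaker inhibitor of growth, a lower number a stronger inhibitor of growth), compound 1 (`CC(C)c1n[nH]c2c(NCc3ccc(-c4ccccn4)cc3)nc(SCCO)nc12`) gives 48 nM and compound 2 (`CC(C)c1n[nH]c2c(NCc3ccc(-c4ccccn4)cc3)nc(SCCn3ccnc3)nc12`) gives 155 nM, the higher of the two numbers so far. The next compound is compound 3 (`CCC(O)CSc1nc(NCc2ccc(-c3ccccn3)cc2)c2[nH]nc(C(C)C)c2n1`), and the change to it reads (1-hydroxypropyl in place of (1H-imidazol-1-yl)methyl on a saturated chain carbon bound to a sulfur). Going by the values given here, one measured step bears on this: a 3.2-fold higher number from compound 1 to compound 2 (0.51 log units; beyond the scatter), a modest step beyond the scatter, with 1H-imidazol-1-yl taking the place of hydroxy. The change to compound 3 removes that imidazole and puts a hydroxy-bearing chain back, so a step of similar size in the reverse direction is expected in this assay. Among the compounds with values here, no measured step covers the remaining difference between the chain of compound 3 and that of compound 1, which widens the range. The expected step is a 2.8-fold lower number from compound 2 to compound 3 (0.45 log units; beyond the scatter), toward a lower number. For compound 3 the estimated value is 55 nM, with a range of 22 nM to 130 nM.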

Compound 3, concentration for 50% growth inhibition: 273 nM
For compound 3 the middle estimate is 5.0-fold (0.70 log units) below the measured one; measured number above the stated range.
By their numbers in this assay, from the lowest: compound 1; then compounds 2 and 3 (each within the scatter of the next).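

In this assay, a hydroxy-bearing chain in place of the imidazole-bearing one does not by itself bring back the number of compound 1: 1-hydroxypropyl in place of (1H-imidazol-1-yl)methyl on a saturated chain carbon bound to a sulfur stays within the scatter (a 1.8-fold higher number from compound 2 to compound 3 (0.25 log units; within the scatter)). The larger step comes with ethyl in place of hydrogen on a saturated chain carbon bound to an oxygen (a 5.7-fold higher number from compound 1 to compound 3 (0.75 log units; beyond the scatter)), so at this position the hydroxy group alone does not set the number, and the added ethyl counts for at least as much as the imidazole. No evidence is at hand to explain either step.

The compounds shown leave open whether methyl in place of that ethyl would give a smaller step from compound 1. They also leave open whether an amine or a carboxylic acid in place of the hydroxy on the two-carbon chain would keep a number close to that of compound 1.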